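Second Fluoro Added to the Aryl Ring of Compound 2

This account rests on a few compounds, and the source may have more. Where it says the series, first, only, none or still open, it means among the compounds named here.

Compound 1, `CN1C[C@@H]2C[C@H]1CN2c1ccc(-c2ccnc3c(-c4cccc5[nH]ncc45)c(-c4ccncc4)nn23)cc1`: 202 nM
Compound 2, `CN1C[C@@H]2C[C@H]1CN2c1ccc(-c2ccnc3c(-c4cccc5[nH]ncc45)c(-c4ccncc4)nn23)cc1F`: "not determined" (no result reported)

In a functional assay on A-375 cells (Homo sapiens) for inhibition, read by MTT assay, with a stated time of 4 days (on this read-out higher numbers stand for weaker inhibition and lower numbers for stronger inhibition), compound 1 gives 202 nM. For compound 2 this assay reports "not determined" (no result reported), so it stands only as a structure, and nothing can be said of how it compares with compound 1. Compound 3, `CN1C[C@@H]2C[C@H]1CN2c1c(F)cc(-c2ccnc3c(-c4cccc5[nH]ncc45)c(-c4ccncc4)nn23)cc1F`, differs from compound 2 by fluoro in place of hydrogen on an aromatic carbon. Among the measured compounds shown here, no step between measured compounds covers this change, so its size is unknown. The expectation is a step in this assay of no more than the usual scatter, in either direction. Compound 1 remains the only measured anchor, and its value of 202 nM gives the reference point. Compound 3 is expected to give an estimated 250 nM in this assay, with a range from 80 nM to 800 nM.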

Compound 3, half-maximal inhibitory concentration: 1250 nM
Beside the measured number, compound 3's estimate is 5.0-fold (0.70 log units) below it, and the stated range ends below it.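

In this assay, among the compounds shown here, compound 2 carries no number, so no step to compound 3 at 1250 nM can be read. The compounds shown leave open what the added fluoro alone does to this read-out. No evidence at hand bears on the result for compound 3.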